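Working notes: acetamido in place of chloro

The source may report more compounds than this note shows. Statements on the series, on what has been measured and on what is new or still open speak of the compounds shown alone.

Measured in a functional assay on HepG2 cells (Homo sapiens) for cytotoxicity, read by MTT assay, with a stated time of 24 h; on this read-out higher numbers stand for weaker inhibition and lower numbers for stronger inhibition:
- compound 1 `O=C1/C(=C/c2cccnc2)CN(S(=O)(=O)c2ccc([N+](=O)[O-])cc2)C/C1=C\c1ccccc1F` gives 12800 nM
- compound 2 `O=C1/C(=C/c2cccnc2)CN(S(=O)(=O)c2ccc(Cl)cc2)C/C1=C\c1ccccc1F` gives 12400 nM

Compound 2 (12400 nM) sits level with compound 1, within the scatter. Compound 3 `CC(=O)Nc1ccc(S(=O)(=O)N2C/C(=C\c3cccnc3)C(=O)/C(=C/c3ccccc3F)C2)cc1` differs from it at one place (acetamido in place of chloro on an aromatic carbon), with acetamido in place of chloro on an aromatic carbon, para to a large group. For the measured compounds named here, the only measured step at that place (a 1.0-fold lower number from compound 1 to compound 2 (0.01 log units; within the scatter)) is chloro in place of nitro and stays within the scatter. Going by these compounds, on that single step, no change beyond the scatter is expected in this assay, though acetamido itself is untested. The expected change is small (a 1.0-fold higher number from compound 2 to compound 3 (0.02 log units; within the scatter)). Compound 3 is estimated at 13000 nM (7000 nM to 24000 nM).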

Compound 3, half-maximal inhibitory concentration: 4560 nM
The estimate for compound 3 lay 2.9-fold (0.45 log units) above the measured number; the whole stated range lies above it.
By their numbers in this assay, from the lowest: compound 3; then compounds 2 and 1 (each within the scatter of the next).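

In this assay this aromatic position, para to a large group, proves responsive: acetamido in place of chloro gives a 2.7-fold lower number from compound 2 to compound 3 (0.43 log units; beyond the scatter) and acetamido in place of nitro gives a 2.8-fold lower number from compound 1 to compound 3 (0.45 log units; beyond the scatter) at the same place, whereas chloro and nitro had stayed within the scatter of each other. Nothing shown bears on why acetamido stands apart.

Going by these compounds, whether the shift needs the whole acetamido group stays open, as an amine or a carboxylic acid at this place would show. Also open, on these data alone, is whether a longer acyl chain moves the number further.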